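A few compounds are considered here, and "the series" means these few. Any claim that something is new, unique, unknown or untested is made for them only; others in the source may bear on it.

Compound 1, `COc1cc(/C=C/c2nnc(NC(=O)c3ccccc3Br)s2)c(Br)c(OC)c1OC`, gives 250 nM in a functional assay on HepG2 cells (Mus musculus) for antiproliferative activity against HepG2 (Homo sapiens), read by MTT assay, with a stated time of 48 h; on this read-out lower numbers stand for stronger inhibition and higher numbers for weaker inhibition.
Compound 2, `COc1cc(/C=C/c2nnc(NC(=O)c3ccc(Br)cc3)s2)c(Br)c(OC)c1OC`, gives 200 nM.
Compound 3, `COc1cc(/C=C/c2nnc(NC(=O)c3cccc(Cl)c3)s2)c(Br)c(OC)c1OC`, gives 150 nM.

Compound 3 holds the lowest of these three numbers, yet the steps leading to it, a 1.3-fold lower number from compound 2 to compound 3 (0.12 log units; within the scatter) and a 1.7-fold lower number from compound 1 to compound 3 (0.22 log units; within the scatter), both sit within the scatter, as does a 1.3-fold lower number from compound 1 to compound 2 (0.10 log units; within the scatter). Compound 4, `COc1cc(/C=C/c2nnc(NC(=O)c3cccc(O)c3)s2)c(Br)c(OC)c1OC`, is the next compound, and it differs from compound 3 by hydroxy in place of chloro on an aromatic carbon. All three measured steps also touched the substituent on the phenyl carried by the carbonyl, and none of them moved the numbers beyond the scatter, yet none brought in a hydroxy group, so the bearing of those steps is indirect. The step of a 1.3-fold higher number from compound 3 to compound 4 (0.12 log units; within the scatter) is therefore expected to stay within the scatter, with no clear direction. Compound 4 is estimated at 200 nM, within a range from 70 nM to 600 nM.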

Compound 4, half-maximal inhibitory concentration: 220 nM
Compound 4: middle estimate off by 1.1-fold (0.04 log units), on the low side, and the stated range covers the measured number.
By their numbers in this assay, from the lowest: compounds 3, 2, 4 and 1 (each within the scatter of the next).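

In this assay, swapping chloro for hydroxy brings a hydrogen-bond donor and acceptor onto this aromatic carbon, yet it gives a 1.5-fold higher number from compound 3 to compound 4 (0.17 log units; within the scatter) and so does not separate the two compounds. The same holds against the bromophenyl amides, with a 1.1-fold higher number from compound 2 to compound 4 (0.04 log units; within the scatter) and a 1.1-fold lower number from compound 1 to compound 4 (0.06 log units; within the scatter), so this part of the molecule has so far accepted all four substituent patterns without a clear shift in the number. Nothing measured here offers an explanation for this result. As far as these compounds go, whether an amine or a carboxylic acid in the same place would also stay within the scatter remains open.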